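A Benzimidazole Change Expected to Leave Potency Unchanged

The compounds below may be only part of what the source reports. "The series", "measured", "known", "first", "only" and "open" are said of these compounds alone.

In an assay on isolated protein for antagonist activity at Bile acid receptor (Homo sapiens), read by TR-FRET and LanthaScreen (on this read-out higher numbers stand for weaker inhibition and lower numbers for stronger inhibition), compound 1 `Cc1ccc2nc([C@H](CC3CCNCC3)N3C(=O)CN(c4ccc(Oc5ccccc5)cc4)C3=O)n(C)c2c1` gives 64000 nM, compound 2 `Cc1ccc2nc([C@H](CC3CCN(CC(C)C)CC3)N3C(=O)CN(c4ccc(Oc5ccccc5)cc4)C3=O)n(C)c2c1` gives 16400 nM, and compound 3 `Cc1ccc2nc([C@H](CC3CCN(C(=O)C(C)C)CC3)N3C(=O)CN(c4ccc(Oc5ccccc5)cc4)C3=O)n(C)c2c1` gives 35 nM, the lowest of the three numbers. Compound 3 stands apart by a 470-fold lower number from compound 2 to compound 3 (2.67 log units; beyond the scatter) and by a 1800-fold lower number from compound 1 to compound 3 (3.26 log units; beyond the scatter), while the remaining step is a 3.9-fold lower number from compound 1 to compound 2 (0.59 log units; beyond the scatter). Every one of these three steps alters only the group on the amine nitrogen in the ring. Compound 4 `CC(C)C(=O)N1CCC(C[C@@H](c2nc3cc(F)ccc3n2C)N2C(=O)CN(c3ccc(Oc4ccccc4)cc3)C2=O)CC1` departs from compound 3 at a different place: 5-fluoro-1-methyl-1H-benzimidazol-2-yl in place of 1,6-dimethyl-1H-benzimidazol-2-yl on a saturated chain carbon bound to an amide-type nitrogen in a ring and a saturated chain carbon. Going by the values given here, none of the measured steps touches this part of the shared core, so no guidance exists for the direction, and no step beyond the scatter is expected. Compound 4 is therefore estimated at 40 nM in this assay, within 12 nM to 130 nM. The expected step is a 1.1-fold higher number from compound 3 to compound 4 (0.06 log units; within the scatter).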

Compound 4, half-maximal inhibitory concentration: 340 nM
For compound 4 the middle estimate is 8.5-fold (0.93 log units) below the measured one, outside the stated range (above it).
By their numbers in this assay, from the lowest: compound 3; then compound 4; then compound 2; then compound 1.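

Replacing 1,6-dimethyl-1H-benzimidazol-2-yl with 5-fluoro-1-methyl-1H-benzimidazol-2-yl gives a 9.7-fold higher number from compound 3 to compound 4 (0.99 log units; beyond the scatter), so in this assay the number responds to this part of the shared core as well as to the group on the amine nitrogen in the ring. The step appears although both groups have the same heavy-atom and hydrogen-bond counts. Nothing available explains this step.

The compounds shown leave open whether the step follows the fluorine, the missing methyl, or both. Unsubstituted 1-methyl-1H-benzimidazol-2-yl and its 5-chloro and 6-fluoro counterparts would help separate these possibilities.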